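Arylidene thiazolidinones on breast cancer cells: a substitution step

The source may hold more compounds than are shown below. What is called first, only, known or untested is meant among the compounds shown, and "the series" means these compounds.

Compound 1 `Cc1ccc(/C=C2/S/C(=N/c3ccccc3)N(Cc3ccncc3)C2=O)cc1`: 36900 nM
Compound 2 `O=C1/C(=C\c2ccc([N+](=O)[O-])cc2)S/C(=N/c2ccccc2)N1Cc1ccncc1`: 13000 nM

In a functional assay on MCF7 cells (Homo sapiens) for cytotoxicity, read by MTT assay, with a stated time of 48 h (a higher number here means a weaker inhibitor, a lower number a stronger inhibitor), compound 2 gives the lowest of the two numbers; compound 1 is the nearest, and the step of a 2.8-fold lower number from compound 1 to compound 2 (0.45 log units; beyond the scatter) lies beyond the scatter. Compound 3 `CCOc1cc(/C=C2/S/C(=N/c3ccccc3)N(Cc3ccncc3)C2=O)ccc1O` differs from compound 2 in one place: 3-ethoxy-4-hydroxyphenyl in place of 4-nitrophenyl on a double-bonded chain carbon bound to a double-bonded ring carbon. Within the data shown here, no measured step covers this change; the only known step concerns a nitro entering for methyl, so a partial return toward compound 1 is possible. Compound 3 is expected at 25000 nM (range 8000 nM to 80000 nM), an expected step of a 1.9-fold higher number from compound 2 to compound 3 (0.28 log units; within the scatter).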

Compound 3, half-maximal inhibitory concentration: 20100 nM
For compound 3 the middle estimate is 1.2-fold (0.09 log units) above the measured one, within the range that was stated.
By their numbers in this assay, from the lowest: compounds 2, 3 and 1 (each within the scatter of the next, the first and the last beyond it).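

In this assay, the step of a 1.5-fold higher number from compound 2 to compound 3 (0.19 log units; within the scatter) and the step of a 1.8-fold lower number from compound 1 to compound 3 (0.26 log units; within the scatter) both lie within the scatter, so compound 3 cannot be told apart from either compound, although compound 1 and compound 2 lie beyond the scatter of each other. This position on a double-bonded chain carbon bound to a double-bonded ring carbon thus also takes 3-ethoxy-4-hydroxyphenyl, with its hydrogen-bond donor, without a step beyond the scatter. The compounds shown leave open what the ethoxy and the hydroxy each contribute alone, and how 4-aminophenyl or 4-carboxyphenyl would read here. No evidence at hand accounts for these steps.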